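The source may report more compounds than this note shows. Statements on the series, on what has been measured and on what is new or still open speak of the compounds shown alone.

Compound 1, `CCCCc1nc(C)c(CC(=O)N(CC)CC)c(=O)n1Cc1ccc(-c2ccccc2-c2nnn[nH]2)cc1`, is the reference point here. Within the data shown here, in an in vivo functional assay on the whole organism for inhibition, with Rattus norvegicus as the target (on this read-out lower numbers stand for an effect already at smaller amounts and higher numbers for an effect only at larger amounts of compound), compound 1 gives 0.089 mg/kg, the highest number among the three compounds measured so far. Compound 2, `CCCCc1nc(C)c(CC(=O)N2CCC[C@H]2C(=O)OC)c(=O)n1Cc1ccc(-c2ccccc2-c2nnn[nH]2)cc1`, gives 0.043 mg/kg in this assay, and compound 3, `CCCCc1nc(C)c(CC(=O)N2CC(C)OC(C)C2)c(=O)n1Cc1ccc(-c2ccccc2-c2nnn[nH]2)cc1`, gives 0.029 mg/kg. Both keep the shared core of compound 1 and alter only the amine part of the amide: a 2.1-fold lower number from compound 1 to compound 2 (0.32 log units; beyond the scatter), and a 3.1-fold lower number from compound 1 to compound 3 (0.49 log units; beyond the scatter). Between the two of them, a 1.5-fold lower number from compound 2 to compound 3 (0.17 log units; within the scatter), so they are not separable on these numbers.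

Compound 4, `CCCCc1nc(C)c(CCC(=O)N2CCCC2)c(=O)n1Cc1ccc(-c2ccccc2-c2nnn[nH]2)cc1`, has not yet been measured in this assay. Its change from compound 1 is ((pyrrolidin-1-yl)carbonyl)methyl in place of diethylcarbamoyl on a saturated chain carbon bound to an aromatic carbon. Among the measured compounds shown here, this differs from the two measured steps in that the chain linking the core to the carbonyl becomes longer as well as the amine becoming a ring, and no measured pair shows the effect of the longer chain by itself. The two measured swaps of the amine part each moved the number modestly downward, so a modest downward step is the most reasonable expectation, tempered by the untested chain change. Compound 4 is therefore expected to give about 0.06 mg/kg in this assay, within a range of 0.02 mg/kg to 0.2 mg/kg, which corresponds to an expected 1.5-fold lower number from compound 1 to compound 4 (0.17 log units; within the scatter).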

Compound 4, dose for half-maximal effect: 0.206 mg/kg
For compound 4 the middle estimate is 3.4-fold (0.54 log units) below the measured one; the measured number lies above the stated range.
By their numbers in this assay, from the lowest: compounds 3 and 2 (each within the scatter of the next); then compound 1; then compound 4.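

Among the compounds shown, this is the first change at this position to raise the number: in this assay the swap gives a 2.3-fold higher number from compound 1 to compound 4 (0.36 log units; beyond the scatter) where the two amine swaps lowered it. The gap is wider against the other two amides, with a 7.1-fold higher number from compound 3 to compound 4 (0.85 log units; beyond the scatter) and a 4.8-fold higher number from compound 2 to compound 4 (0.68 log units; beyond the scatter) so compound 4 stands apart from all three compounds with the shorter link, and a longer chain carrying a pyrrolidine amide is the only arrangement here that moves the number upward. Nothing available here accounts for this rise.

The change from (diethylcarbamoyl)methyl to 2-((pyrrolidin-1-yl)carbonyl)ethyl alters the chain and the amine together, so the compounds shown cannot say which of the two carries the rise. As far as these compounds go, a compound with ((pyrrolidin-1-yl)carbonyl)methyl on the original short link, paired with one bearing 2-(diethylcarbamoyl)ethyl on the longer chain, would separate the two effects, and whether a carboxylic acid in place of the amide would be tolerated at this position also stays open.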